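A few compounds are considered here, and "the series" means these few. Any claim that something is new, unique, unknown or untested is made for them only; others in the source may bear on it.

The measurements come from a functional assay on the whole organism with Rattus norvegicus as the target; a lower number here means that less compound is needed, a higher number that more compound is needed for the effect. Compound 1, with structure `Nc1nc2ccc(OCC(F)(F)F)cc2s1`, gives 6.5 mg/kg in this assay. Compound 2, with structure `Nc1nc2ccc(OC(F)(F)C(F)(F)F)cc2s1`, gives 2.5 mg/kg in this assay. Compound 3, with structure `N=c1sc2cc(OC(F)(F)F)ccc2n1CC(=O)O`, gives > 10 mg/kg in this assay. That result for compound 3 is the limit of > 10 mg/kg in this assay, at which 1 of the 3 values shown sits, a limit and not a number: compound 3 is known to lie beyond that limit, nothing more. Among the measured compounds shown here, no measured step links compound 3 to compound 1 or compound 2, and no step between any two measured compounds that differ in one place is available at all.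

Compound 4, with structure `N=c1sc2cc(OC(F)(F)F)ccc2n1CCSc1ccccc1`, differs from compound 3 in a single place: (phenylsulfanyl)methyl in place of carboxy on a saturated chain carbon bound to an aromatic nitrogen. For the measured compounds named here, the starting point is itself a limit, and no measured pair shows what this kind of change does in this assay. The expected step of a number no higher from compound 3 to compound 4 (the limit leaves the size open) is uncertain in size and in direction, and is best taken as nothing beyond the usual scatter. For compound 4 the expected value in this assay is 10 mg/kg, with a range from 3 mg/kg to 30 mg/kg, and a real chance that this assay again reports only a limit.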

Compound 4, dose for half-maximal effect: 4.5 mg/kg
Compound 4: middle estimate off by 2.2-fold (0.35 log units), on the high side; low and high end bracket the measured number.
By their numbers in this assay, from the lowest: compounds 2, 4 and 1 (each within the scatter of the next, the first and the last beyond it). At a limit, above all of these: compound 3.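

In this assay, among the compounds shown here, this is the first measured step at this position: (phenylsulfanyl)methyl in place of carboxy on a saturated chain carbon bound to an aromatic nitrogen gives an at least 2.2-fold lower number from compound 3 to compound 4 (0.34 log units; beyond the scatter). The change removes the carboxy group and brings in a larger group with a six-membered aromatic ring of carbon only, and with it the series gains a real number at this position instead of only a limit. The step can be given only as a minimum, because the result for compound 3 is a limit and not a number: the limit of > 10 mg/kg in this assay, at which 1 of the 4 values shown sits.

The swap changes the whole group at once, so the compounds shown cannot say whether the gain comes from losing the carboxy group, from the sulfur or from the phenyl ring. As far as these compounds go, what a methyl ester or an amide of the acid would do at this position stays open, as does the effect of an oxygen in place of the sulfur, a longer chain, or a substituted phenyl ring.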